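Three measured compounds and one still to come

The source may hold more compounds than are shown below. What is called first, only, known or untested is meant among the compounds shown, and "the series" means these compounds.

compound 1 `Cc1nc(-c2ccccc2)oc1COc1ccc2c(c1)OCC2CC(=O)O`: 7.15%
compound 2 `Cc1cc(COc2ccc3c(c2)OCC3CC(=O)O)nn1-c1ccccc1`: 0.98%
compound 3 `Cc1nc(-c2cccs2)sc1COc1ccc2c(c1)OCC2CC(=O)O`: 35.2%

In a functional assay on CHO cells for agonist activity at Free fatty acid receptor 1 (Homo sapiens), read by FLIPR and calcium flux, tested at 100 nM (a lower number here means a weaker effect, a higher number a stronger effect of the compound at the concentration tested), compound 3 gives the highest of the three numbers; compound 1 lies beyond the scatter below it, and compound 2 lies further below still. Compound 4 `Cc1ccccc1-c1nc(C)c(COc2ccc3c(c2)OCC3CC(=O)O)s1` differs from compound 3 in one place: 2-methylphenyl in place of thiophen-2-yl on an aromatic carbon. Among the compounds with values here, no two measured compounds differ in just one place, so no comparable step is available. Replacing the thiophen-2-yl with a 2-methylphenyl is a change of the whole group on that ring carbon, and a modest downward step in this assay is expected, though a result within the scatter would not surprise. The expected step is a number 9.2 percentage points lower from compound 3 to compound 4 (within the scatter). Compound 4 is therefore estimated at 26%, with a range from 8% to 52%.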

Compound 4, a percentage reported as activity, at one concentration (the size of the read-out at that concentration, not a potency): 10.7%
Compound 4: the middle estimate sits 15.3 percentage points above what was measured, and the stated range covers the measured number.
By their numbers in this assay, from the lowest: compounds 2, 1 and 4 (each within the scatter of the next); then compound 3.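

Within the data shown here, this is the first comparison in the set that changes one place only, and it shows that the group on this aromatic carbon, next to the ring nitrogen and the ring sulfur, matters. In this assay, putting 2-methylphenyl in place of thiophen-2-yl gives a number 24.5 percentage points lower from compound 3 to compound 4 (beyond the scatter). No measurement shown explains this drop.

The compounds shown do not separate the effect of swapping the ring from that of its methyl group. On these data alone, how a furan-2-yl or a 3-methylphenyl would read on this carbon also stays open.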